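This account rests on a few compounds, and the source may have more. Where it says the series, first, only, none or still open, it means among the compounds named here.

Compound 1 `COc1cccc(CNCCCNc2ccnc3cc(-c4ccc(C(C)(C)C)cc4)ccc23)c1O` gives 9.47 in a physicochemical assay for acid dissociation. Compound 2 `CC(C)(C)c1ccc(-c2ccc3c(NCCCNCc4ccco4)ccnc3c2)cc1` gives 9.47 in this assay, so the step of no change at the digits printed from compound 1 to compound 2 (within the scatter) left the reading where it stood when furan-2-yl replaced 2-hydroxy-3-methoxyphenyl on a saturated chain carbon bound to an amine nitrogen. Compound 2 therefore stands level with compound 1 at the digits shown. Compound 3 `N#Cc1ccc(Cc2ccc3c(NCCCNCc4ccco4)ccnc3c2)cc1` differs from compound 2 by 4-cyanobenzyl in place of 4-(tert-butyl)phenyl on an aromatic carbon, a change made on an aromatic carbon of the shared core. Going by the values given here, no measured step tests this place directly; the single step available, from compound 1 to compound 2, stayed within the scatter, and the amine-bearing chain of compound 2 is kept unchanged in compound 3. Compound 3 is accordingly expected to show no step beyond the scatter, a number 0.07 log units lower from compound 2 to compound 3 (within the scatter). The estimate for compound 3 is 9.4, with a range from 9 to 9.8.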

Compound 3, acid dissociation constant: 9.47
Beside the measured number, compound 3's estimate is 0.07 log units below it; measured number inside the range.
By their numbers in this assay, from the lowest: compounds 1, 2 and 3 (each within the scatter of the next).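

In this assay, the aromatic carbon of the shared core now has a step of its own: 4-cyanobenzyl in place of 4-(tert-butyl)phenyl gives no change at the digits printed from compound 2 to compound 3 (within the scatter). Taken with the earlier step on the saturated chain carbon, this means that changes at two separate places have now left the reading within the scatter, including one that brings in a nitrile. Nothing at hand bears on the reason for this result.

From the compounds shown here alone, whether the reading would hold with a carboxylic acid or a primary amine on this aromatic carbon remains open. Also open, going by these compounds, is how it would respond to a longer chain in place of the amine-bearing chain, which compounds 1, 2 and 3 all share.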